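Methoxycarbonyl Added to the Biphenyl of a Bile Acid Receptor Agonist

The source may report more compounds than this note shows. Statements on the series, on what has been measured and on what is new or still open speak of the compounds shown alone.

Two compounds share one core. Compound 1 `Cc1ccccc1-n1nc(C)c2c1NC(=O)[C@H](C)S[C@@H]2c1ccc(OCc2ccccc2)cc1` is reported in an assay on isolated protein for agonist activity at Bile acid receptor (Homo sapiens), read by AlphaScreen, with a stated time of 30 min (a higher number here means that more compound is needed for the effect, a lower number that less compound is needed), as "not active" (no number reported). Among the measured compounds shown here, compound 2 `Cc1ccccc1-n1nc(C)c2c1NC(=O)[C@H](C)S[C@@H]2c1ccc(-c2ccccc2)cc1` gives 990 nM in this assay, the only number among the measured compounds, with compound 1 beside it without a number. Compound 3 `COC(=O)c1ccc(-c2ccc([C@H]3S[C@@H](C)C(=O)Nc4c3c(C)nn4-c3ccccc3C)cc2)cc1` differs from compound 2 by methoxycarbonyl in place of hydrogen on an aromatic carbon. For the measured compounds named here, no measured pair shows such a change, so only a small step is expected, toward slightly less compound needed, not beyond the usual scatter. Compound 3 is estimated at 700 nM, within 200 nM to 3000 nM. That expectation amounts to a step of a 1.4-fold lower number from compound 2 to compound 3 (0.15 log units; within the scatter).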

Compound 3, half-maximal effective concentration: "not active" (no number reported)
For compound 3 the study gives words and no number, so the estimate cannot be set against anything.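

Among the compounds shown here, compound 3, like compound 1, is reported only in words, so no step from compound 2 to compound 3 can be read. Nothing shown explains this result. The compounds shown leave open how far methoxycarbonyl in place of hydrogen shifts the number of compound 2.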